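A Methoxy Added to the Phenyl of Compound 1

The source may hold more compounds than are shown below. What is called first, only, known or untested is meant among the compounds shown, and "the series" means these compounds.

In a functional assay on the whole organism (strain albino) for inhibition, with Rattus norvegicus as the target, read by paw edema, with a stated time of 4 h, at a dose of 0.28 mmol/kg by the oral route (a lower number here means less inhibition, a higher number more inhibition at the dose given (going by the name of the read-out)), compound 1 `C=CCn1c(SCC(=O)c2ccccc2)nnc1-c1ccccc1` gives 66%, the lowest of the three numbers seen. Compound 2 `COc1ccc(-c2nnc(SC/C(=N/O)c3ccccc3)n2-c2ccccc2)cc1` gives 80% and compound 3 `COc1ccc(-c2nnc(SC/C(=N/O)c3ccccc3)n2-c2ccccc2)cc1OC` gives 81%; both stand beyond the scatter above compound 1. Compound 4 `C=CCn1c(SCC(=O)c2ccccc2)nnc1-c1ccc(OC)cc1` differs from compound 1 only by methoxy in place of hydrogen on an aromatic carbon. Within the data shown here, one measured step bears on this change: a number 1 percentage points higher from compound 2 to compound 3 (within the scatter), the same methoxy in place of hydrogen on an aromatic carbon, which stayed within the scatter, though on a different core. From that single step one expects in this assay no shift beyond the scatter. Compound 4 is therefore estimated at 68%, between 55% and 80%, an expected step of a number 2 percentage points higher from compound 1 to compound 4 (within the scatter).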

Compound 4, a percentage reported as inhibition, in the whole organism at one dose (the size of the read-out at that dose, not a potency): 67%
Compound 4: middle estimate off by 1 percentage points, on the high side, and the stated range covers the measured number.
By their numbers in this assay, from the lowest: compounds 1 and 4 (each within the scatter of the next); then compounds 2 and 3 (each within the scatter of the next).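

In this assay, phenyl gives way to 4-methoxyphenyl with a number 1 percentage points higher from compound 1 to compound 4 (within the scatter). The earlier compounds showed this methoxy change on one core only, and it now leaves the read-out inside the scatter on a second core as well, so the two steps agree: the same change on two cores in this assay, a number 1 percentage points higher (within the scatter) from compound 2 to compound 3 and a number 1 percentage points higher (within the scatter) from compound 1 to compound 4, 0 percentage points apart, within the scatter of two such steps

Both steps concern methoxy alone, so they say nothing about how an amine, a carboxylic acid or a longer alkoxy chain would behave at this place. As far as these compounds go, whether any such group could move the inhibition beyond the scatter remains open.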